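Trifluoromethyl added to the aryl ring of compound 2

The compounds below may be only part of what the source reports. "The series", "measured", "known", "first", "only" and "open" are said of these compounds alone.

Compound 2 `O=C1C2CCCCN2C(=O)N1CN1CCN(c2ccccc2)CC1` is one of two compounds examined in an assay on isolated protein for binding affinity to Adrenergic receptor alpha-1 (Rattus norvegicus), read by radioligand binding; a higher number here means a weaker inhibitor, a lower number a stronger inhibitor. For compound 2 the value > 1000 nM is a limit of the assay and not a number. Compound 1 `O=C1C2CCCN2C(=O)N1CN1CCN(c2cccc(C(F)(F)F)c2)CC1`, which has a different core and a trifluoromethyl on its aryl ring, gives > 1000 nM in this assay, again a limit. For the measured compounds named here, both values sit at the limit of > 1000 nM in this assay, at which 2 of the 2 values shown sit, so no step between measured compounds can be counted, and compound 2 stands at the same limit as the only other measured compound. Compound 3 `O=C1C2CCCCN2C(=O)N1CN1CCN(c2cccc(C(F)(F)F)c2)CC1` differs from compound 2 by trifluoromethyl in place of hydrogen on an aromatic carbon. Because compound 1 sits at the limit of > 1000 nM in this assay, at which 2 of the 2 values shown sit, while already bearing this group, compound 3 is expected to remain at the limit, and the expected step that the limit leaves unreadable from compound 2 to compound 3 is none beyond the scatter. Compound 3 is thus estimated at 3000 nM, within a range from 800 nM to 20000 nM, most likely reported again only as a limit.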

Compound 3, inhibition constant: > 1000 nM
Compound 3: only a limit was reported (the forecaster's own chance of this, stated with the estimate: 85%); the middle value does not contradict the limit.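

No step can be read between compound 2 and compound 3 in this assay, because each value is a limit of the assay and not a number: the limit of > 1000 nM in this assay, at which 3 of the 3 values shown sit.

The compounds shown leave open whether trifluoromethyl in place of hydrogen on an aromatic carbon changes affinity at all.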